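Trifluoromethyl replacing chloro on a nitrofuran amide series

The source may hold more compounds than are shown below. What is called first, only, known or untested is meant among the compounds shown, and "the series" means these compounds.

Measured compounds:
Compound 1, `COc1cccc(-c2csc(NC(=O)c3ccc([N+](=O)[O-])o3)n2)c1`, gives 58700 nM in an ADME assay on Vero cells (Chlorocebus sabaeus) for cytotoxicity, read by MTT assay, with a stated time of 72 h; on this read-out lower numbers stand for stronger inhibition and higher numbers for weaker inhibition.
Compound 2, `O=C(Nc1nc(-c2cccc(F)c2)cs1)c1ccc([N+](=O)[O-])o1`, gives 51600 nM in this assay.
Compound 3, `O=C(Nc1nc(-c2cccc(Cl)c2)cs1)c1ccc([N+](=O)[O-])o1`, gives 43700 nM in this assay.

The three compounds share one core and differ only in the group on the outer six-membered ring. Compound 3 gives one of three numbers that all lie within the scatter of one another: the steps of a 1.3-fold lower number from compound 1 to compound 3 (0.13 log units; within the scatter) and a 1.2-fold lower number from compound 2 to compound 3 (0.07 log units; within the scatter), like a 1.1-fold lower number from compound 1 to compound 2 (0.06 log units; within the scatter), are too small to count as real change. Compound 4, `O=C(Nc1nc(-c2cccc(C(F)(F)F)c2)cs1)c1ccc([N+](=O)[O-])o1`, differs from compound 3 by trifluoromethyl in place of chloro on an aromatic carbon. The step from compound 2 to compound 3 is the closest parallel, a swap of one halogen-type substituent for another at the same place, and it stayed within the scatter, as did the swaps from methoxy. No step beyond the scatter is therefore expected in this assay. Compound 4 is expected to give about 42000 nM, between 21000 nM and 84000 nM. The estimated step of a 1.0-fold lower number from compound 3 to compound 4 (0.02 log units; within the scatter) remains within the scatter.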

Compound 4, half-maximal inhibitory concentration: 23900 nM
For compound 4 the middle estimate is 1.8-fold (0.24 log units) above the measured one; the range from low to high includes it.
By their numbers in this assay, from the lowest: compounds 4, 3, 2 and 1 (each within the scatter of the next, the first and the last beyond it).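

Within the data shown here, this position does respond in this assay, if only modestly: trifluoromethyl gives the first steps beyond the scatter (a 2.2-fold lower number from compound 2 to compound 4 (0.33 log units; beyond the scatter)) and (a 2.5-fold lower number from compound 1 to compound 4 (0.39 log units; beyond the scatter)). Against chloro it stays within the scatter (a 1.8-fold lower number from compound 3 to compound 4 (0.26 log units; within the scatter)), so compound 3 and compound 4 cannot be told apart. Nothing measured here explains these steps. On these data alone, whether an amine or a carboxylic acid in this place would give a larger step remains open, as does how changes elsewhere on the shared core would register.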